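Compound 3 to Compound 4 at the Assay Limit

The source may hold more compounds than are shown below. What is called first, only, known or untested is meant among the compounds shown, and "the series" means these compounds.

In a functional assay on HepG2 cells (Homo sapiens) for antiproliferative activity, read by MTT assay, with a stated time of 48 h (a higher number here means a weaker inhibitor, a lower number a stronger inhibitor), compound 1 `CCN(CC)CCNC(=O)c1ccc(C(CC)(CC)c2ccc(OCCC(O)(CC)CC)c(C)c2)n1CC` gives 230 nM. Compound 2 `CCn1c(C(=O)NCC#N)ccc1C(CC)(CC)c1ccc(OCCC(O)(CC)CC)c(C)c1` gives > 50000 nM, which is a limit and not a number. Compound 3 `C#CC(C)OC(=O)c1ccc(C(CC)(CC)c2ccc(OCCC(O)(CC)CC)c(C)c2)n1CC` gives > 50000 nM, also a limit. Compound 3 thus stands at the limit of > 50000 nM in this assay, at which 2 of the 3 values shown sit.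

Compound 4 `CCOc1ccc(NC(=O)c2ccc(C(CC)(CC)c3ccc(OCCC(O)(CC)CC)c(C)c3)n2CC)cc1` changes compound 3 on the carbonyl carbon, with (4-ethoxyphenyl)amino in place of (1-methylprop-2-yn-1-yl)oxy on a carbonyl carbon. The steps bearing on this are an at least 210-fold higher number from compound 1 to compound 3 (2.33 log units; beyond the scatter) and an at least 210-fold higher number from compound 1 to compound 2 (2.33 log units; beyond the scatter), both large. Both remove the (2-(diethylamino)ethyl)amino of compound 1, and compound 4 lacks it too, so no recovery of that size is expected. Only a small step toward a lower number is expected in this assay: an at least 1.2-fold lower number from compound 3 to compound 4 (0.09 log units; that floor lies within the scatter). The estimate for compound 4 is 40000 nM, with an expected range of 8000 nM to 100000 nM.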

Compound 4, half-maximal inhibitory concentration: > 50000 nM
Compound 4 gave a limit, no number; the forecaster's own chance of this, stated with the estimate: 55%; middle value at least 1.2-fold (0.09 log units) away from the limit.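

Compound 4 keeps the amide of compound 1 but carries 4-ethoxyphenyl on the amide-type nitrogen, and in this assay the large step remains: an at least 210-fold higher number from compound 1 to compound 4 (2.33 log units; beyond the scatter). An aromatic ring on that nitrogen thus joins cyanomethyl in giving only a limit, and compound 4 joins the compounds at that limit: the limit of > 50000 nM in this assay, at which 3 of the 4 values shown sit. The steps among compound 2, compound 3 and compound 4 cannot be read, as all three values are limits.

Going by these compounds, whether another amine on the chain, such as a pyrrolidine or a dimethylamino group, would keep a measurable number stays open.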